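The compounds below may be only part of what the source reports. "The series", "measured", "known", "first", "only" and "open" are said of these compounds alone.

Measured so far in a functional assay on A-375 cells (Homo sapiens) for cytotoxicity, read by MTT assay, with a stated time of 72 h; a lower number here means a stronger inhibitor, a higher number a weaker inhibitor:
- compound 1 `O=C1c2c[n+]([O-])c3ccccc3c2C(=O)c2c1c1ccccc1n2Cc1cn(C[C@H](O)CO)nn1` gives 350 nM
- compound 2 `O=C1c2c[n+]([O-])c3ccccc3c2C(=O)c2[nH]c3ccccc3c21` gives 660 nM

Compound 2 stands within the scatter of compound 1, so these two values do not separate. Compound 3 `O=C1c2c[n+]([O-])c3ccccc3c2C(=O)c2c1c1ccccc1n2CCCN1CCC(O)CC1` differs from compound 2 by one change (3-(4-hydroxypiperidin-1-yl)propyl in place of hydrogen on an aromatic nitrogen), with 3-(4-hydroxypiperidin-1-yl)propyl in place of hydrogen on an aromatic nitrogen. Among the measured compounds shown here, the only measured step at that nitrogen is (a 1.9-fold higher number from compound 1 to compound 2 (0.28 log units; within the scatter)), where hydrogen replaces (1-(2,3-dihydroxypropyl)-1H-1,2,3-triazol-4-yl)methyl. It is a different group, so it offers limited guidance, but it gives no reason to expect a shift beyond the scatter in this assay here. The expected step is small (a 1.7-fold lower number from compound 2 to compound 3 (0.22 log units; within the scatter)). For compound 3 the estimate is 400 nM, with an expected range (140 nM to 1200 nM).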

Compound 3, half-maximal inhibitory concentration: 240 nM
The estimate for compound 3 lay 1.7-fold (0.22 log units) above the measured number, and the stated range covers the measured number.
By their numbers in this assay, from the lowest: compounds 3, 1 and 2 (each within the scatter of the next, the first and the last beyond it).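

In this assay, substitution on this aromatic nitrogen now gives a step beyond the scatter, though a modest one: with 3-(4-hydroxypiperidin-1-yl)propyl in place of hydrogen, the step is a 2.8-fold lower number from compound 2 to compound 3 (0.44 log units; beyond the scatter). The two substituted compounds do not separate, the step being a 1.5-fold lower number from compound 1 to compound 3 (0.16 log units; within the scatter), so this nitrogen accepts two quite different chains with similar numbers. No measurement available here explains the step.

Going by these compounds, whether the hydroxy group on the piperidine or the propyl chain carries the step remains open. An unsubstituted piperidine, a morpholine or a longer chain at this nitrogen would test that.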